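A few compounds are considered here, and "the series" means these few. Any claim that something is new, unique, unknown or untested is made for them only; others in the source may bear on it.

In a functional assay on A549 cells (Homo sapiens) for inhibition, read by MTT assay, with a stated time of 24 h (on this read-out lower numbers stand for stronger inhibition and higher numbers for weaker inhibition), compound 1 `CC1(C)[C@H]2CC[C@]1(C)N(Cc1cn(-c3cccc(F)c3)nn1)C(=O)C2` gives 180 nM, compound 2 `CC1(C)[C@H]2CC[C@]1(C)N(Cc1cn(-c3ccccc3Br)nn1)C(=O)C2` gives 130 nM and compound 3 `CC1(C)[C@H]2CC[C@]1(C)N(Cc1cn(-c3ccc(C#N)cc3)nn1)C(=O)C2` gives 140 nM. These three share a core and differ only in the substituted phenyl group on an aromatic nitrogen. Compound 3 lies within the usual scatter of both of the others, so the three numbers cannot be ranked.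

The compound still to be measured, compound 4 `CC1(C)[C@H]2CC[C@]1(C)N(Cc1cn(-c3ccccc3C#N)nn1)C(=O)C2`, has 2-cyanophenyl in place of 4-cyanophenyl on an aromatic nitrogen. Going by the values given here, no measured compound carries the 2-cyanophenyl group, so the evidence is indirect. Changing the phenyl group has so far produced only small steps: a 1.4-fold lower number from compound 1 to compound 2 (0.14 log units; within the scatter) and a 1.3-fold lower number from compound 1 to compound 3 (0.11 log units; within the scatter). The closest parallel, which exchanges 2-bromophenyl for 4-cyanophenyl, is a 1.1-fold higher number from compound 2 to compound 3 (0.03 log units; within the scatter). All three steps stay within the scatter, so no clear shift in either direction is expected in this assay. With so few compounds, however, a larger surprise cannot be ruled out. The expected change is only slight, a 1.1-fold higher number from compound 3 to compound 4 (0.03 log units; within the scatter), and this estimate lies within the scatter. For compound 4 the estimated value is 150 nM, with an expected range from 70 nM to 320 nM.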

Compound 4, half-maximal inhibitory concentration: 100 nM
The estimate for compound 4 lay 1.5-fold (0.18 log units) above the measured number; the range from low to high includes it.
By their numbers in this assay, from the lowest: compounds 4, 2, 3 and 1 (each within the scatter of the next).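

In this assay, moving the nitrile around the phenyl ring, with the same atoms joined differently, gives a 1.4-fold lower number from compound 3 to compound 4 (0.15 log units; within the scatter), so 4-cyanophenyl and 2-cyanophenyl cannot be told apart on this read-out. Exchanging one group for another at the same ring position also gives a small step, as cyano in place of bromo yields a 1.3-fold lower number from compound 2 to compound 4 (0.11 log units; within the scatter) and leaves those two compounds indistinguishable as well. The largest step among the four compounds, a 1.8-fold lower number from compound 1 to compound 4 (0.26 log units; within the scatter), also stays within the scatter, so across the fluoro, bromo and cyano phenyl groups shown here, neither the substituent nor its place on the ring has yet produced a clear change.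

No measurement is available here that could account for the size of these steps. Still open, as far as these compounds go, is whether a substituent of a different kind, such as an amine or a carboxylic acid on the phenyl ring, or a longer alkyl chain in place of the phenyl group, would move the number beyond the scatter in this assay.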